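Methoxy placement on the aryl ring of a tetrazolylcarboxamide series

A few compounds are considered here, and "the series" means these few. Any claim that something is new, unique, unknown or untested is made for them only; others in the source may bear on it.

Three compounds of the series have been run in a functional assay on the whole organism for inhibition, with Rattus norvegicus as the target, at a dose of 1 mg/kg by the oral route; on this read-out higher numbers stand for a stronger effect at the one dose given and lower numbers for a weaker effect. Compound 1 `COc1ccc(-c2cc(Cl)cc(C(=O)Nc3nn[nH]n3)n2)cc1OC` gives 15% in this assay, and compound 2 `CC(C)c1ccc(-c2cc(Cl)cc(C(=O)Nc3nn[nH]n3)n2)cc1` gives 14%. Compound 3 `COc1cc(C(=O)Nc2nn[nH]n2)nc(-c2ccccc2OC)c1` gives 41%, the highest of the three numbers; its gap to compound 1 and its gap to compound 2 both lie beyond the usual scatter, so compound 3 stands apart from the other two on this read-out. Compound 1 and compound 2 sit within the scatter of each other, and nothing can be said about an order between them.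

Among the compounds with values here, no pair of measured compounds differs in one place only, so no single measured step is available to calibrate the next change. Compound 4 `COc1ccc(-c2cc(OC)cc(C(=O)Nc3nn[nH]n3)n2)cc1` differs from compound 3 as follows: 4-methoxyphenyl in place of 2-methoxyphenyl on an aromatic carbon.

Within the data shown here, the only guide is that compound 3, the one compound carrying a 2-methoxyphenyl group, gives 41%, while the compounds with other aryl substitution give lower numbers. On that basis a downward step is expected from compound 3 to compound 4, larger than the scatter but not necessarily back to the level of compound 1 and compound 2: the expected step is a number 14 percentage points lower from compound 3 to compound 4 (beyond the scatter). Compound 4 is estimated at 27%, with a range from 10% to 45%.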

Compound 4, a percentage reported as inhibition, in the whole organism at one dose (the size of the read-out at that dose, not a potency): 25%
Compound 4: the middle estimate sits 2 percentage points above what was measured; the range from low to high includes it.
By their numbers in this assay, from the lowest: compounds 2, 1 and 4 (each within the scatter of the next, the first and the last beyond it); then compound 3.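

Working from the one-place change in the series, moving the methoxy group from 2-methoxyphenyl to 4-methoxyphenyl gives a number 16 percentage points lower from compound 3 to compound 4 (beyond the scatter) in this assay, with the aryl group on the same aromatic carbon next to the ring nitrogen. Within the data shown here, the two groups have the same heavy atoms and the same counts of donors and acceptors, so this step isolates the placement of the methoxy group on the aryl ring, which the earlier compounds could not do, as no pair among them differed in one place only. No measurement bearing on the reason for this step is at hand.

Open, from the compounds shown here alone, is how 3-methoxyphenyl would read at this position, and whether 2-ethoxyphenyl or 2-hydroxyphenyl would keep the higher number seen with 2-methoxyphenyl. Also open, going by these compounds, is whether the same step appears with a chlorine in place of the methoxy group on the shared core, and since the read-out comes from a single oral dose, it shows a stronger effect for compound 3 than for compound 4 at that dose only.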